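Changing the Aryl Group on the Ring Nitrogen: An Expectation

The compounds below may be only part of what the source reports. "The series", "measured", "known", "first", "only" and "open" are said of these compounds alone.

Compound 1 `CCc1ccc(-n2nc(-c3ccc(C(F)(F)F)cc3O)nc2-c2ccccc2O)cc1` gives 107% in a functional assay on PC-12 cells (Rattus norvegicus) for cytotoxicity, read by MTT assay, with stated times of 2 h and 24 h, tested at 10 uM; a lower number here means a weaker effect, a higher number a stronger effect of the compound at the concentration tested.
Compound 2 `CC(C)c1ccc(-n2nc(-c3ccc(C(F)(F)F)cc3O)nc2-c2ccccc2O)cc1` gives 108% in this assay.
Compound 3 `Oc1cc(C(F)(F)F)ccc1-c1nc(-c2ccccc2O)n(-c2ccc(OC(F)(F)F)cc2)n1` gives 92.5% in this assay.

Compound 3 stands lowest of the three numbers, as a number 14.5 percentage points lower from compound 1 to compound 3 (beyond the scatter) and a number 15.5 percentage points lower from compound 2 to compound 3 (beyond the scatter) show, both beyond the scatter. Compound 4 `Oc1cc(C(F)(F)F)ccc1-c1nc(-c2ccccc2O)n(-c2ccccc2F)n1` differs from compound 3 in one place: 2-fluorophenyl in place of 4-(trifluoromethoxy)phenyl on an aromatic nitrogen. For the measured compounds named here, no measured step puts 2-fluorophenyl on the aromatic nitrogen. The two steps that changed this same group, from ethyl or isopropyl to trifluoromethoxy, each lowered the number modestly, and compound 4 carries none of those groups. A value between those of compound 3 and compound 1 seems plausible, so the expected step of a number 7.5 percentage points higher from compound 3 to compound 4 (within the scatter) lies within the scatter. Compound 4 is estimated at 100% in this assay, with a range from 85% to 115%.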

Compound 4, a percentage reported as activity, at one concentration (the size of the read-out at that concentration, not a potency): 100%
The estimate for compound 4 equals the measured number at the digits printed; the range from low to high includes it.
By their numbers in this assay, from the lowest: compounds 3, 4, 1 and 2 (each within the scatter of the next, the first and the last beyond it).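

Until now, only the group carried on the phenyl ring had changed, always on a 4-substituted phenyl. With 2-fluorophenyl on the aromatic nitrogen, this assay shows no step beyond the scatter: a number 7.5 percentage points higher from compound 3 to compound 4 (within the scatter), a number 8 percentage points lower from compound 2 to compound 4 (within the scatter) and a number 7 percentage points lower from compound 1 to compound 4 (within the scatter). Compound 4 thus sits within the scatter of all three earlier compounds, and nothing available gives a reason for these numbers.

On these data alone, whether a phenyl ring carrying an amine or a carboxylic acid would stay in this range remains open. As far as these compounds go, what the fluorine of 2-fluorophenyl contributes on its own also remains open.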